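A few compounds are considered here, and "the series" means these few. Any claim that something is new, unique, unknown or untested is made for them only; others in the source may bear on it.

Measured so far:
- compound 1, `CCc1cccc(NC(=O)N[C@@H](C)c2ccccc2)c1`, in an ADME assay on the whole organism with Oryza sativa as the target, tested at 10 uM (on this read-out higher numbers stand for a weaker effect at the one concentration tested and lower numbers for a stronger effect), gives 86%
- compound 2, `CC(C)c1cccc(NC(=O)N[C@H](C)c2ccccc2)c1`, in this assay gives 44%

Of these two numbers, compound 2 stands lowest: its nearest neighbour is compound 1, which sits higher by a gap that is beyond the usual scatter, so on this read-out compound 2 shows the stronger effect of the pair. Within the data shown here, nothing more can be said of that pair, since the two compounds differ in more than one place and no single step between them is set out.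

The next compound, compound 3, `CC(C)c1cccc(NC(=O)N[C@@H](C)c2ccccc2)c1`, has not yet been measured. It differs from compound 2 as follows: the two compounds have the same atoms and bonds and differ only in configuration as drawn: 1 of 1 stereo elements differ; a stereocentre at a saturated chain carbon is drawn R in compound 2 and S in compound 3. Among the measured compounds shown here, no measured pair in this set shows what such a change in configuration alone does in this assay, so the size and direction of the step from compound 2 to compound 3 is open. The expectation here is a moderate rise, with wide uncertainty, as a step of a number 21 percentage points higher from compound 2 to compound 3 (beyond the scatter). For compound 3 the estimated value in this assay is 65%, expected to fall between 35% and 95%.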

Compound 3, a percentage reported as activity, at one concentration (the size of the read-out at that concentration, not a potency): 86%
For compound 3 the middle estimate is 21 percentage points below the measured one, within the range that was stated.
By their numbers in this assay, from the lowest: compound 2; then compounds 1 and 3 (each within the scatter of the next).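

In this assay, the configuration at the stereocentre proves to matter on its own, with a number 42 percentage points higher from compound 2 to compound 3 (beyond the scatter), and since lower numbers stand for a stronger effect, the form drawn R in compound 2 is the stronger of this pair. This large step can be tied to the configuration and to nothing else in the structure, because of one plain point: the fact that compounds 2 and 3 differ only in the configuration as drawn

The other new comparison points the opposite way: methyl in place of hydrogen on a saturated chain carbon bound to an aromatic carbon and a saturated chain carbon gives no change at the digits printed from compound 1 to compound 3 (within the scatter), so in this pair the extra methyl brings no visible change in the read-out.

From the compounds shown here alone, what stays open is whether the effect of configuration seen between these two compounds also holds for a different group at that place, such as a longer chain, a tert-butyl group or a methoxy group. The compounds shown also leave open how a compound with the ethyl group of compound 1 and the configuration of compound 2 would behave, so the one large step remains a single observation rather than a general rule.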